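Cytotoxicity notes: from compound 3 to compound 4

The compounds below may be only part of what the source reports. "The series", "measured", "known", "first", "only" and "open" are said of these compounds alone.

compound 1 `CC(C)(C)OC(=O)Nc1ncc(C(Oc2ccc3cc(Br)ccc3c2)c2ccc(Cl)cc2)s1`: > 50000 nM
compound 2 `COCCNc1ncc(C(Oc2ccc3cc(Br)ccc3c2)c2ccc(Cl)cc2)s1`: "not toxic" (no number reported)
compound 3 `O=C(Nc1ncc(C(Oc2ccc3cc(Br)ccc3c2)c2ccc(Cl)cc2)s1)c1cc(F)c(F)cc1F`: "not toxic" (no number reported)

In an ADME assay on HepG2 2.2.15 cells (Homo sapiens) for cytotoxicity (a lower number here means that less compound is tolerated, a higher number that more compound is tolerated), compound 1 is reported only as a limit of the assay, > 50000 nM, which is the line (the limit of > 50000 nM in this assay, at which 1 of the 3 values shown sits). Compound 2 is given as "not toxic" (no number reported), and compound 3 likewise as "not toxic" (no number reported), so compound 3 stands without a single number, as does compound 2, and nothing among the three shows a separation beyond the scatter. Compound 4 `N#Cc1cccc(C(=O)Nc2ncc(C(Oc3ccc4cc(Br)ccc4c3)c3ccc(Cl)cc3)s2)c1` differs from compound 3 by 3-cyanophenyl in place of 2,4,5-trifluorophenyl on a carbonyl carbon. For the measured compounds named here, no measured step exists here; the expectation in this assay is no movement beyond the scatter, with compound 4 most likely again reported as a limit. Compound 4 is estimated at 60000 nM, between 20000 nM and 200000 nM.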

Compound 4, half-maximal cytotoxic concentration: > 50000 nM
Compound 4 was reported as a limit; the forecaster's own chance of this, stated with the estimate: 75%; the middle value lies beyond the limit too.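

Compound 1 and compound 4 are both reported only as limits, so no step can be read between them: the limit of > 50000 nM in this assay, at which 2 of the 4 values shown sit. The compounds shown leave open where any of them would reach a numerical value in this assay.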